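A few compounds are considered here, and "the series" means these few. Any claim that something is new, unique, unknown or untested is made for them only; others in the source may bear on it.

Among the measured compounds shown here, compound 2 `CC/C(=N\N=C(\N)S)c1ccc(Br)cc1` is one of two compounds measured in a functional assay on B16 cells (Mus musculus) for inhibition, with a stated time of 3 days (on this read-out higher numbers stand for weaker inhibition and lower numbers for stronger inhibition), where compound 2 gives 2000 nM. For the measured compounds named here, its only neighbour is compound 1 `CC/C(=N\N=C(\N)S)c1ccc(Cl)cc1`, which in this assay gives 2900 nM; the step of a 1.5-fold lower number from compound 1 to compound 2 (0.16 log units; within the scatter) lies within the scatter, so the two numbers cannot be told apart, even though the number of compound 2 is the smaller one on paper.

Compound 3 `CC/C(=N\N=C(\N)S)c1ccc(OC)cc1` has not yet been measured. It differs from compound 2 in one place: methoxy in place of bromo on an aromatic carbon. Going by the values given here, the single measured step concerns exchanging one halogen for another and says nothing about a methoxy group, so the data bear on this change only indirectly. With the shared core unchanged, compound 3 is expected to land near the two halogen analogues, with the expected step being a 1.8-fold higher number from compound 2 to compound 3 (0.24 log units; within the scatter). The exchange for a methoxy group is untried here, and the range is set wide. Compound 3 is estimated in this assay at 3500 nM, between 800 nM and 15000 nM.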

Compound 3, half-maximal inhibitory concentration: 4000 nM
Estimate against measurement, compound 3: 1.1-fold (0.06 log units) below, within the range that was stated.
By their numbers in this assay, from the lowest: compounds 2, 1 and 3 (each within the scatter of the next).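

Among the compounds shown here, until this result, the aromatic carbon had carried only halogens. Methoxy, with 2 heavy atoms and 1 hydrogen-bond acceptor, now shows that a group other than a halogen can sit there in this assay without a step beyond the scatter, the readings being (a 2.0-fold higher number from compound 2 to compound 3 (0.30 log units; within the scatter)) and (a 1.4-fold higher number from compound 1 to compound 3 (0.14 log units; within the scatter)). The three groups at this position therefore cannot be ranked on these numbers, and no available measurement bears on the reason.

As far as these compounds go, whether an amine, a carboxylic acid or a longer chain such as butoxy at this carbon would move the number beyond the scatter remains open. From the compounds shown here alone, it is also open whether the same tolerance would hold if the ethyl chain on the shared core were replaced by a methyl or a propyl chain.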